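Swapping imidazole for pyrazole at a solubility limit

A few compounds are considered here, and "the series" means these few. Any claim that something is new, unique, unknown or untested is made for them only; others in the source may bear on it.

Compound 1 `CC(C)(C)c1nc(-c2cccs2)c2c(N)c(C#N)c(N)nc2n1`: 56000 nM
Compound 2 `CC(C)(C)c1nc(-c2ccccc2)c2c(N)c(C#N)c(N)nc2n1`: 4000 nM
Compound 3 `CC(C)(C)c1nc(-c2ncc[nH]2)c2c(N)c(C#N)c(N)nc2n1`: < 1000 nM, a limit

In a physicochemical assay for solubility, in phosphate buffer, with a stated time of 18 h (a higher number here means a more soluble compound, a lower number a less soluble compound), compound 3 gives < 1000 nM, which is a limit and not a number. It stands lowest of the three, as shown by an at least 56-fold lower number from compound 1 to compound 3 (1.74 log units; beyond the scatter) and by an at least 4.0-fold lower number from compound 2 to compound 3 (0.60 log units; beyond the scatter). Compound 4 `CC(C)(C)c1nc(-c2ccn[nH]2)c2c(N)c(C#N)c(N)nc2n1` has 1H-pyrazol-5-yl in place of 1H-imidazol-2-yl on an aromatic carbon. Earlier swaps on this carbon also include a 14-fold lower number from compound 1 to compound 2 (1.15 log units; beyond the scatter). Compound 4 keeps the atoms of compound 3, joined differently. A smaller step than those is expected, in no firm direction, and perhaps none beyond the scatter. The expected change is a number no lower from compound 3 to compound 4 (the limit leaves the size open). For compound 4 the estimate is 1000 nM, with an expected range of 250 nM to 4000 nM.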

Compound 4, solubility: 13500 nM
Estimate against measurement, compound 4: 14-fold (1.13 log units) below; the whole stated range lies below it.
By their numbers in this assay, from the lowest: compound 2; then compound 4; then compound 1. At a limit, below all of these: compound 3.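

Exchanging 1H-imidazol-2-yl for 1H-pyrazol-5-yl joins the same atoms differently, yet this assay shows an at least 13-fold higher number from compound 3 to compound 4 (1.13 log units; beyond the scatter). Compound 4 also sits between the two earlier rings, with a 3.4-fold higher number from compound 2 to compound 4 (0.53 log units; beyond the scatter) and a 4.1-fold lower number from compound 1 to compound 4 (0.62 log units; beyond the scatter), so at this position two rings with identical counts of atoms, donors and acceptors need not read alike. As far as these compounds go, compound 3 stands at a limit and not a number, so the true size of the first step stays open: the limit of < 1000 nM in this assay, at which 1 of the 4 values shown sits.

From the compounds shown here alone, what an amine or a carboxylic acid on this carbon would give remains open. So does whether this swap behaves the same way on another core.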